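Trifluoromethoxy for phenoxy in a cytotoxicity check

The compounds below may be only part of what the source reports. "The series", "measured", "known", "first", "only" and "open" are said of these compounds alone.

Measured so far:
compound 1 `CCOC(=O)CCCCCOc1cccc(CN(C(=O)c2ccc(-c3cccc4ccccc34)cc2)C(C)C)c1`, > 26000 nM
compound 2 `CCOC(=O)CCCCCOc1cccc(CN(C(=O)c2ccc(-c3cccc(Oc4ccccc4)c3)cc2)C(C)C)c1`, > 19600 nM

In an ADME assay on Raji cells (Homo sapiens) for cytotoxicity, read by CellTiter-Glo and resazurin assay, with a stated time of 72 h (on this read-out lower numbers stand for an effect already at smaller amounts and higher numbers for an effect only at larger amounts of compound), compound 2 gives only a limit, > 19600 nM. Compound 1 likewise gives only a limit, > 26000 nM. Both results sit at limits, the limit of > 19600 nM in this assay, at which 1 of the 2 values shown sits, and (the limit of > 26000 nM in this assay, at which 1 of the 2 values shown sits), so no true number is known for either. Compound 3 `CCOC(=O)CCCCCOc1cccc(CN(C(=O)c2ccc(-c3cccc(OC(F)(F)F)c3)cc2)C(C)C)c1` differs from compound 2 by trifluoromethyl in place of phenyl on an oxygen on an aromatic ring. Because compound 2 reached only a limit (the limit of > 19600 nM in this assay, at which 1 of the 2 values shown sits), a step of no more than the usual scatter is expected in this assay, with the move from compound 2 to compound 3 estimated as a step that the limit leaves unreadable from compound 2 to compound 3. Compound 3 is expected to give about 30000 nM, within 15000 nM to 60000 nM, most likely again as a limit.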

Compound 3, half-maximal effective concentration: > 26000 nM
Compound 3: no number, only a limit; the forecaster's own chance of this, stated with the estimate: 85%; the middle value is on the limit's open side.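

In this assay compound 3 gives only a limit, as do compound 1 and compound 2, so the steps among these compounds cannot be read. The compounds shown leave open at what concentration any of them affects these cells.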